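Pyrimidin-2-yl in place of pyridin-2-yl: expected step

The source may report more compounds than this note shows. Statements on the series, on what has been measured and on what is new or still open speak of the compounds shown alone.

Of the compounds shown here, three have been measured in an assay on HEK293 cells for displacement of a labelled ligand from D(4) dopamine receptor (Homo sapiens), read by scintillation counting, with a stated time of 90 min; on this read-out lower numbers stand for stronger inhibition and higher numbers for weaker inhibition. Compound 1 `Cc1cccc(NC(=O)CN2CCN(c3cccc4ccccc34)CC2)c1` gives 1.65 nM. Compound 3 `Cc1cccc(NC(=O)CN2CCC(c3ccccc3)CC2)c1` gives 1.4 nM. Compound 2 `Cc1cccc(NC(=O)CCN2CCN(c3ccccn3)CC2)c1` gives 32.2 nM, the highest of the three numbers; its gap to compound 1 and its gap to compound 3 both lie beyond the scatter, so compound 2 stands as the weakest binder among those measured. Among the compounds with values here, no pair of measured compounds differs in a single place, so no single structural step can be read off from the numbers in hand.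

Compound 4 `Cc1cccc(NC(=O)CCN2CCN(c3ncccn3)CC2)c1` has not been measured. It differs from compound 2 in one place: pyrimidin-2-yl in place of pyridin-2-yl on an amine nitrogen in a ring. Within the data shown here, none of the measured compounds shows what this exchange does in this assay. The change is small in count, and the expectation is for no step beyond the scatter, with a slight lean toward a higher number. On that basis compound 4 is estimated at 40 nM, with a range from 12 nM to 130 nM. The step this estimate implies, a 1.2-fold higher number from compound 2 to compound 4 (0.09 log units; within the scatter), is expected to stay within the scatter of repeated measurements.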

Compound 4, inhibition constant: 33 nM
For compound 4 the middle estimate is 1.2-fold (0.08 log units) above the measured one; measured number inside the range.
By their numbers in this assay, from the lowest: compounds 3 and 1 (each within the scatter of the next); then compounds 2 and 4 (each within the scatter of the next).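

Within the data shown here, the first single-place step is now in hand: in this assay the exchange of pyridin-2-yl for pyrimidin-2-yl on the amine nitrogen in the ring gives a 1.0-fold higher number from compound 2 to compound 4 (0.01 log units; within the scatter). At this position, then, an added ring nitrogen and an added hydrogen-bond acceptor in the six-membered aromatic ring, with the heavy-atom count unchanged, produce no step beyond the scatter, a reading that rests on this single pair of compounds. Nothing measured here gives a reason for this outcome.

The compounds shown leave open whether this position stays as undemanding with other replacements, such as pyrazin-2-yl or pyridin-4-yl, or with an amine or a methoxy group carried on the pyrimidin-2-yl ring. They also leave open whether the same exchange gives a comparable step on a shorter or longer chain, and compounds 1 and 3 differ from compound 2 and compound 4 in more than one place, so no single structural change can yet be tied to those gaps.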